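The source may report more compounds than this note shows. Statements on the series, on what has been measured and on what is new or still open speak of the compounds shown alone.

Measured compounds in a functional assay on B16 cells (Mus musculus) for cytotoxicity, read by MTT assay, with a stated time of 72 h; a lower number here means a stronger inhibitor, a higher number a weaker inhibitor:
Compound 1 `COc1cccc(/C=C/C(=O)Nc2cc(C(=O)c3cc(OC)c(OC)c(OC)c3)ccc2OC)c1` gives 3100 nM.
Compound 2 `COc1ccc(/C=C/C(=O)Nc2cc(C(=O)c3cc(OC)c(OC)c(OC)c3)cc(OC)c2OC)cc1OC` gives 1300 nM.
Compound 3 `COc1cccc(/C=C/C(=O)Nc2cc(C(=O)c3cc(OC)c(OC)c(OC)c3)cc(OC)c2OC)c1` gives 6700 nM.

Compound 3 has the highest number of the three, so it is the weakest of the measured set in this assay: compound 1 lies below it by a 2.2-fold higher number from compound 1 to compound 3 (0.33 log units; beyond the scatter), compound 2 further below by a 5.2-fold higher number from compound 2 to compound 3 (0.71 log units; beyond the scatter). Both known steps concern a methoxy group, one on the core and one on the cinnamoyl-side aryl ring; the second shows that a change on that aryl ring can move the number by a modest but clear amount.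

Compound 4 `COc1cc(C(=O)c2cc(OC)c(OC)c(OC)c2)cc(NC(=O)/C=C/c2cc(F)c(F)c(F)c2)c1OC` changes compound 3 at exactly that aryl ring: 3,4,5-trifluorophenyl in place of 3-methoxyphenyl on a double-bonded chain carbon bound to a double-bonded chain carbon. For the measured compounds named here, none of the measured steps swaps a methoxy for fluorine, so the only guide is the size of the step between compound 2 and compound 3, taken as a scale for a modest change on this ring, with no direction implied. A modest shift in this assay in either direction is therefore possible, and the expected step of a 1.3-fold lower number from compound 3 to compound 4 (0.13 log units; within the scatter) is set near zero with a wide range.

For compound 4 in this assay the estimate is 5000 nM, with a range from 1500 nM to 20000 nM.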

Compound 4, half-maximal inhibitory concentration: 5200 nM
Estimate against measurement, compound 4: 1.0-fold (0.02 log units) below; the range from low to high includes it.
By their numbers in this assay, from the lowest: compound 2; then compounds 1, 4 and 3 (each within the scatter of the next, the first and the last beyond it).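

In this assay, for the compounds shown here, the first exchange at this place that removes the methoxy group altogether, 3,4,5-trifluorophenyl in place of 3-methoxyphenyl, gives a step within the scatter (a 1.3-fold lower number from compound 3 to compound 4 (0.11 log units; within the scatter)), so an aryl group carrying only fluorine cannot be told apart here from one carrying a single methoxy group. The step from the 3,4-dimethoxyphenyl group is beyond the scatter (a 4.0-fold higher number from compound 2 to compound 4 (0.60 log units; beyond the scatter)), which shows that the advantage of compound 2 in this assay holds against a second, quite different aryl group and not only against 3-methoxyphenyl. Nothing on hand accounts for either step.

Still open, from the compounds shown here alone, is whether the 3,4-dimethoxyphenyl pattern is the specific requirement at this place, or whether other aryl groups, such as a phenyl ring bearing a hydroxyl group, an amine or a carboxylic acid, would reach the same level or go beyond it. Also open, going by these compounds, is whether the 3,4,5-trifluorophenyl group would behave the same way on the core of compound 1, which lacks one methoxy group of the core of compound 3.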